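Shortening an Ether Side Chain: Expected Cytotoxicity Unchanged

The source may hold more compounds than are shown below. What is called first, only, known or untested is meant among the compounds shown, and "the series" means these compounds.

Compound 1 `CCOCCCNC(=O)c1csc(Nc2ccc(Cl)c(Cl)c2)n1`: in an ADME assay on MDCK cells (Canis lupus familiaris) for cytotoxicity, with a stated time of 48 h (a lower number here means that less compound is tolerated, a higher number that more compound is tolerated), compound 1 gives > 100000 nM, a limit of the assay.
Compound 2 `CCOCCCNC(=O)c1csc(Nc2ccc(Cl)cc2)n1`: in this assay compound 2 gives > 100000 nM, also a limit.
Compound 3 `Cc1cc(Nc2nc(C(=O)NCCCOC(C)C)cs2)ccc1Cl`: in this assay compound 3 gives > 100000 nM, again a limit.

Compound 3 therefore stands at the limit, and it is not alone there: the limit of > 100000 nM in this assay, at which 3 of the 3 values shown sit. No number below that limit has been seen for any of the three compounds.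

Compound 4 `CCOCCCNC(=O)c1csc(Nc2ccc(Cl)c(C)c2)n1` differs from compound 3 in one place: hydrogen in place of methyl on a saturated chain carbon bound to an oxygen on a saturated carbon and a saturated chain carbon. For the measured compounds named here, the only measured step between two compounds, a step that the two limits leave unreadable from compound 1 to compound 2, concerns a different change and is itself hidden by the two limits, so it gives no guide to size or direction. Nothing among the shown values suggests any step beyond the scatter, so compound 4 is expected to sit at the limit too, meaning an expected step that the limit leaves unreadable from compound 3 to compound 4. Compound 4 is thus estimated at 150000 nM, within a range from 50000 nM to 500000 nM.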

Compound 4, half-maximal cytotoxic concentration: 52000 nM
Estimate against measurement, compound 4: 2.9-fold (0.46 log units) above; the range from low to high includes it.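

For the compounds shown here, with ethoxy in place of isopropoxy, compound 4 is the first compound to give a number rather than a limit in this assay, yet this change reads only as an at least 1.9-fold lower number from compound 3 to compound 4 (0.28 log units; that floor lies within the scatter), so it cannot be said to lower the number beyond normal repeat variation. The two changes on an aromatic carbon are no clearer, with methyl in place of hydrogen reading as an at least 1.9-fold lower number from compound 2 to compound 4 (0.28 log units; that floor lies within the scatter) and methyl in place of chloro reading as an at least 1.9-fold lower number from compound 1 to compound 4 (0.28 log units; that floor lies within the scatter). Compound 4 therefore stands alone with a measured number, while the other compounds remain at the limit: the limit of > 100000 nM in this assay, at which 3 of the 4 values shown sit.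

On these data alone, the true values of compound 1, compound 2 and compound 3 stay hidden, so the real size of all three steps remains unknown. As far as these compounds go, it also remains open how the number would respond to a methoxy group or a longer butoxy chain at this place.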